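Compound 3 to compound 4: methyl to methoxy

This account rests on a few compounds, and the source may have more. Where it says the series, first, only, none or still open, it means among the compounds named here.

Measured in an unclassified assay for pharmacokinetics, read by NMR, at pH 7.5, tested at 2 mg/mL; a higher number here means that the compound lasts longer, a lower number that the compound disappears faster:
- Compound 1 `COc1ccc(/N=N\c2ccc(F)c(C(=O)Nc3cnc4[nH]nc(OC)c4c3)c2F)cc1`: > 24 h (limit)
- Compound 2 `COc1n[nH]c2ncc(NC(=O)c3c(F)ccc(/N=N\c4ccc(F)cc4)c3F)cc12`: > 24 h (limit)
- Compound 3 `COc1n[nH]c2ncc(NC(=O)c3c(F)ccc(/N=N\c4ccccc4C)c3F)cc12`: > 24 h (limit)

The whole series stands at the limit of > 24 h in this assay, at which 3 of the 3 values shown sit. Compound 3 therefore has no exact half-life, only a limit.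

Compound 4 `COc1ccccc1/N=N\c1ccc(F)c(C(=O)Nc2cnc3[nH]nc(OC)c3c2)c1F` replaces 2-methylphenyl with 2-methoxyphenyl, the methoxy being ortho to a large group: methoxy in place of methyl on an aromatic carbon.

The measured steps bearing on this change are a step that the two limits leave unreadable from compound 1 to compound 3, a step that the two limits leave unreadable from compound 2 to compound 3 and a step that the two limits leave unreadable from compound 1 to compound 2. None gives a size, so no step beyond the scatter can be forecast in either direction in this assay.

The expected change is a step that the limit leaves unreadable from compound 3 to compound 4.

The estimate for compound 4 is 40 h, with an expected range of 20 h to 100 h.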

Compound 4, half-life: > 24 h
Compound 4 gave a limit, no number; the forecaster's own chance of this, stated with the estimate: 75%; the middle value lies beyond the limit too.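

In this assay, going by these compounds alone, compound 4 gives only a limit, as do compounds 1, 2 and 3, so no step from compound 4 to any of them can be read: the limit of > 24 h in this assay, at which 4 of the 4 values shown sit. On these data alone, how long any of these four compounds actually lasts, and whether methoxy and methyl differ at all here, stays open.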